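A few compounds are considered here, and "the series" means these few. Any claim that something is new, unique, unknown or untested is made for them only; others in the source may bear on it.

Three compounds share one core, shown by compound 1 `CC1=CC[C@H](C(C)(C)NC(=S)N/N=C/c2ccccc2O)CC1`. In a functional assay on K562 cells (Homo sapiens) for inhibition, read by sulforhodamine B assay, with a stated time of 48 h (on this read-out lower numbers stand for stronger inhibition of growth and higher numbers for weaker inhibition of growth), compound 1 gives 800 nM. Compound 2 `CC1=CC[C@H](C(C)(C)NC(=S)N/N=C/c2ccccc2Cl)CC1` gives 5600 nM in this assay, and compound 3 `CC1=CC[C@H](C(C)(C)NC(=S)N/N=C/c2ccc(Cl)cc2)CC1` gives 300 nM. Compound 3 stands lowest of the three numbers: a 2.7-fold lower number from compound 1 to compound 3 (0.43 log units; beyond the scatter), and a 19-fold lower number from compound 2 to compound 3 (1.27 log units; beyond the scatter). The remaining step went the other way, a 7.0-fold higher number from compound 1 to compound 2 (0.85 log units; beyond the scatter).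

Compound 4 `CC1=CC[C@H](C(C)(C)NC(=S)N/N=C/c2ccco2)CC1` differs from compound 3 by furan-2-yl in place of 4-chlorophenyl on a carbon with a double bond to nitrogen. Among the measured compounds shown here, no measured step exchanges the aromatic ring itself for a different ring; the three steps among compound 1, compound 2 and compound 3 only alter the substituent on the same ring or where it sits, yet they already span modest to large movements in this assay. For the measured compounds named here, the ring exchange leading to compound 4 is therefore expected to shift this assay beyond the scatter, most likely toward a higher number, because compound 3 holds the lowest number so far at 300 nM and every measured departure from it has risen; the spread of the estimate must be wide. Compound 4 is expected at 1500 nM, within 400 nM to 6000 nM. This corresponds to an expected step of a 5.0-fold higher number from compound 3 to compound 4 (0.70 log units; beyond the scatter).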

Compound 4, concentration for 50% growth inhibition: 100 nM
Beside the measured number, compound 4's estimate is 15-fold (1.18 log units) above it; the measured number lies below the stated range.
By their numbers in this assay, from the lowest: compound 4; then compound 3; then compound 1; then compound 2.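

In this assay, a five-membered aromatic ring with 1 hetero atom on the carbon with a double bond to nitrogen gives the lowest number of the series, and this position is thus not limited to the substituted six-membered rings of compound 1, compound 2 and compound 3 (a 3.0-fold lower number from compound 3 to compound 4 (0.48 log units; beyond the scatter)). The same exchange also lowers the number against the other two compounds (an 8.0-fold lower number from compound 1 to compound 4 (0.90 log units; beyond the scatter); a 56-fold lower number from compound 2 to compound 4 (1.75 log units; beyond the scatter)), and the latter is the largest step in the series, so neither the hydroxy nor the chloro substituent is needed for growth inhibition in these cells. No supporting measurement accounts for the gain of compound 4 over compound 3.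

The compounds shown leave open whether the movement follows the ring size or the ring oxygen, a question that an unsubstituted phenyl group would help to separate. They also leave open how far the furan-2-yl tolerates further substitution, for example a methyl group or a dimethylamino group, and whether the gain persists when the rest of the shared core changes.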